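Benzothiazole amides: swapping the sulfanyl substituent

The source may report more compounds than this note shows. Statements on the series, on what has been measured and on what is new or still open speak of the compounds shown alone.

Three compounds have numbers in a functional assay on HCT-116 cells (Homo sapiens) for antiproliferative activity, read by MTT assay, with a stated time of 72 h; a lower number here means a stronger inhibitor, a higher number a weaker inhibitor. Compound 1 `O=C(Cc1nnc(NC(=O)c2ccc(Cl)cc2)s1)N/N=C/c1ccc(O)cc1` gives 68300 nM. Compound 2 `O=C(CSc1nc2ccccc2[nH]1)Nc1ccc2nc(NC(=O)c3ccc(C(F)(F)F)cc3)sc2c1` gives 3760 nM, the lowest of the two measured numbers; compound 1 sits at a higher value, a gap beyond the scatter. Compound 3 `Cn1c(CNC(=O)c2cccs2)nnc1SCC(=O)Nc1cccc(Cl)c1` returns only a limit, > 100000 nM, and not a number; this is the limit of > 100000 nM in this assay, at which 1 of the 3 values shown sits. No two of these compounds differ in a single place, so no measured step is available in the series.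

Compound 4 `O=C(CSc1cccc(O)c1)Nc1ccc2nc(NC(=O)c3ccc(C(F)(F)F)cc3)sc2c1` keeps the core of compound 2 and changes one thing: 3-hydroxyphenyl in place of 1H-benzimidazol-2-yl on a sulfur. Among the compounds with values here, there is no measured pair to calibrate this exchange, so the direction of the step is open; a moderate change in either direction beyond the scatter is possible, and no shift beyond the scatter is equally plausible. Compound 4 is expected at 7000 nM, with a range of 1500 nM to 30000 nM. This corresponds to an expected step of a 1.9-fold higher number from compound 2 to compound 4 (0.27 log units; within the scatter), a slight loss that still leaves compound 4 well clear of the limit seen for compound 3.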

Compound 4, half-maximal inhibitory concentration: 510 nM
For compound 4 the middle estimate is 14-fold (1.14 log units) above the measured one, outside the stated range (below it).
By their numbers in this assay, from the lowest: compound 4; then compound 2; then compound 1. At a limit, above all of these: compound 3.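

In this assay, the group on the sulfur of the shared core turns out to be a place that responds to change, with a 7.4-fold lower number from compound 2 to compound 4 (0.87 log units; beyond the scatter). The single carbon ring of 3-hydroxyphenyl therefore gives the lower number of this pair, and the two-ring 1H-benzimidazol-2-yl is not needed to reach this level of antiproliferative activity on this core. Nothing in the data shown bears on why the number falls with this exchange.

The compounds shown leave open whether the hydroxyl or the single carbon ring carries the step: a plain phenyl or a 3-methoxyphenyl on the same sulfur would separate the two. Also open, on these data alone, is whether the sulfur itself matters, which an oxygen or a methylene in its place would test.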